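Removing One Chloro From a Dichloropurine Core

The source may report more compounds than this note shows. Statements on the series, on what has been measured and on what is new or still open speak of the compounds shown alone.

The two measured compounds are compound 1 `ClCc1ccc(Cn2cnc3nc(Cl)nc(Cl)c32)cc1` and compound 2 `ClCc1ccccc1Cn1cnc2ncnc(Cl)c21`. In a functional assay on SK-MEL-5 cells (Homo sapiens) for cytotoxicity, read by sulforhodamine B assay, with a stated time of 48 h (a higher number here means a weaker inhibitor of growth, a lower number a stronger inhibitor of growth), compound 1 gives 2450 nM. In this assay compound 2 gives 1380 nM. The two numbers lie within the usual scatter of each other, so nothing can be said about an order between them, and compound 1 stands alongside compound 2 rather than apart from it.

The unmeasured compound is compound 3 `ClCc1ccc(Cn2cnc3ncnc(Cl)c32)cc1`. It is reached from compound 1 by a single change, (hydrogen in place of chloro on an aromatic carbon), in words hydrogen in place of chloro on an aromatic carbon. Among the measured compounds shown here, compound 2 also carries only one chloro on its core, although it differs from compound 1 in more than one place.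

For the measured compounds named here, no pair of measured compounds differing in one place is available, so no measured step guides this change. Compound 3 is expected to land close to compound 1, with the step of a 1.5-fold lower number from compound 1 to compound 3 (0.19 log units; within the scatter) expected to stay within the scatter, because compound 2 gives 1380 nM. Compound 3 is therefore estimated at 1600 nM, in a range from 600 nM to 4500 nM.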

Compound 3, concentration for 50% growth inhibition: 2810 nM
Beside the measured number, compound 3's estimate is 1.8-fold (0.24 log units) below it; the measured number falls inside the stated range.
By their numbers in this assay, from the lowest: compounds 2, 1 and 3 (each within the scatter of the next, the first and the last beyond it).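

In this assay, the chloro on the aromatic carbon between two ring nitrogen atoms can now be judged on its own, and replacing it with hydrogen gives a 1.1-fold higher number from compound 1 to compound 3 (0.06 log units; within the scatter), so compound 1 and compound 3 cannot be told apart at this position. The earlier compounds shown here could not show this, since compound 1 and compound 2 differ in more than one place and offered no single-change step to read. The result therefore shows that, in this pair, the chloro at this position can be exchanged for hydrogen without a difference beyond the scatter, although no measurement is available here that would explain this outcome.

The compounds shown leave open whether an amine, a methoxy group or a longer chain on the same aromatic carbon would also stay within the scatter of compound 1. They also leave open what the other chloro on the core contributes, and whether the chloromethyl group matters, as neither group is exchanged in any single-change step here.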